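The compounds below may be only part of what the source reports. "The series", "measured", "known", "first", "only" and "open" are said of these compounds alone.

In an ADME assay on L02 cells (Homo sapiens) for cytotoxicity, read by MTT assay (a lower number here means a stronger inhibitor, a higher number a weaker inhibitor), three esters sharing one core have been measured. Compound 1 `CCC(=O)Oc1cc(/C=C/C(=O)c2ccc(OC)c3c2OC(C)(C)C=C3)ccc1OC` gives > 10000 nM, which is a limit of the assay and not a number. Compound 2 `CCCCC(=O)Oc1cc(/C=C/C(=O)c2ccc(OC)c3c2OC(C)(C)C=C3)ccc1OC` gives > 10000 nM, again a limit. Compound 3 `COc1ccc(/C=C/C(=O)c2ccc(OC)c3c2OC(C)(C)C=C3)cc1OC(=O)C(C)C` gives > 10000 nM, also a limit. It therefore has no exact position, and it sits with the other two: the limit of > 10000 nM in this assay, at which 3 of the 3 values shown sit.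

Compound 4 `COc1ccc(/C=C/C(=O)c2ccc(OC)c3c2OC(C)(C)C=C3)cc1OC(=O)CCl` differs from compound 3 in one place: chloromethyl in place of isopropyl on a carbonyl carbon. In words, this is chloromethyl in place of isopropyl on a carbonyl carbon.

Three measured steps alter the chain carried by that carbonyl carbon: a step that the two limits leave unreadable from compound 1 to compound 2, a step that the two limits leave unreadable from compound 1 to compound 3 and a step that the two limits leave unreadable from compound 2 to compound 3. None of them has a readable size, and none brings in chlorine, so they give no firm direction for this change.

The expected change is small and uncertain, and it is estimated as a step that the limit leaves unreadable from compound 3 to compound 4. The assay may well report only a limit again. For compound 4, the expected value is an estimated 12000 nM, with a range from 4000 nM to 30000 nM.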

Compound 4, half-maximal inhibitory concentration: > 10000 nM
Compound 4 gave a limit, no number; the forecaster's own chance of this, stated with the estimate: 70%; the middle value does not contradict the limit.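

Compound 4 also gives only a limit, not a number, so its steps from compound 1, compound 2 and compound 3 cannot be read, and all four compounds stand together: the limit of > 10000 nM in this assay, at which 4 of the 4 values shown sit.

The compounds shown leave open what exact value any of these esters has in this assay, and whether the chain on the carbonyl carbon changes that value at all.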